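This account rests on a few compounds, and the source may have more. Where it says the series, first, only, none or still open, it means among the compounds named here.

Compound 1 `Cc1nc2c(Br)c(Br)c(Br)c(Br)c2n1CC#N` and compound 2 `Cc1nc2c(Br)c(Br)c(Br)c(Br)c2n1CCC#N` share one core and were both tested in a functional assay on CCRF-CEM cells (Homo sapiens) for cytotoxicity, read by MTT assay, with a stated time of 24 h, tested at 50 uM; a higher number here means a weaker effect of the compound at the concentration tested, a lower number a stronger effect. In this assay compound 1 gives 2% and compound 2 gives 2%. The change from compound 2 to compound 1 is cyano in place of cyanomethyl on a saturated chain carbon bound to an aromatic nitrogen, and the step it made is no change at the digits printed from compound 2 to compound 1 (within the scatter). Compound 3 `N#CCCCCn1cnc2c(Br)c(Br)c(Br)c(Br)c21` gives 1% in this assay; how its core differs from that of compound 2 is not broken down here. Compound 4 `N#CCCCn1cnc2c(Br)c(Br)c(Br)c(Br)c21` is not yet measured. From compound 3 to compound 4 the change is cyano in place of cyanomethyl on a saturated chain carbon, three bonds along the chain from an aromatic nitrogen, the same kind of change as from compound 2 to compound 1, though not the same: there the carbon is bound to an aromatic nitrogen, here it is three bonds along the chain from an aromatic nitrogen. A step of a number 1 percentage points higher from compound 3 to compound 4 (within the scatter) is expected, because no change at the digits printed from compound 2 to compound 1 (within the scatter) stayed within the scatter. Compound 4 is therefore estimated at 2%, between 0% and 12%.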

Compound 4, a percentage reported as activity, at one concentration (the size of the read-out at that concentration, not a potency): 2%
Estimate against measurement, compound 4: no gap at the digits printed; measured number inside the range.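

In this assay, putting cyano in place of cyanomethyl on the chain gives a small step: a number 1 percentage points higher from compound 3 to compound 4 (within the scatter). Set beside the earlier step, the change carries from one core to the other with no difference that can be told apart: the same change on two cores in this assay, no change at the digits printed (within the scatter) from compound 2 to compound 1 and a number 1 percentage points higher (within the scatter) from compound 3 to compound 4, 1 percentage points apart, within the scatter of two such steps. For the compounds shown here, this shows only that the change leaves the read-out flat on these two cores at a single concentration, where all the numbers are low; it does not show that the same would hold at lower concentrations, or on a core where the read-out is not already this low.

The compounds shown leave open what an amine or a carboxylic acid in place of the nitrile would give, and how a chain longer than 4-cyanobutyl would behave. Also open, as far as these compounds go, is what replacing the bromine atoms on the core would do.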